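The source may hold more compounds than are shown below. What is called first, only, known or untested is meant among the compounds shown, and "the series" means these compounds.

In a functional assay on CCRF-CEM cells (Homo sapiens) for cytotoxicity, with a stated time of 72 h (a lower number here means a stronger inhibitor, a higher number a weaker inhibitor), compound 1 `CCOC(=O)/C=C/C=C/C=C/C=C/c1ccc[nH]1`, which carries a 1H-pyrrol-2-yl group, gives 1340 nM. Compound 2 `CCOC(=O)/C=C/C=C/C=C/C=C/c1nccs1`, with 1,3-thiazol-2-yl instead, reads > 10000 nM, which is a limit of the assay and not a number. Compound 3 `CCOC(=O)/C=C/C=C/C=C/C=C/c1ccco1`, with furan-2-yl, reads > 10000 nM, also a limit and not a number. Compound 3 thus sits at the limit of > 10000 nM in this assay, at which 2 of the 3 values shown sit.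

Compound 4 `CCOC(=O)/C=C/C=C/C=C/C=C/c1[nH]ccc1Cl` differs from compound 3 on a double-bonded chain carbon bound to a double-bonded chain carbon: a group of 6 heavy atoms (4 carbon, 1 nitrogen, 1 chlorine; one five-membered aromatic ring with 1 hetero atom) in place of a group of 5 heavy atoms (4 carbon, 1 oxygen; one five-membered aromatic ring with 1 hetero atom), on a double-bonded chain carbon bound to a double-bonded chain carbon. Among the measured compounds shown here, two measured steps bear on this change. Replacing 1H-pyrrol-2-yl gave an at least 7.4-fold higher number from compound 1 to compound 3 (0.87 log units; beyond the scatter), and the other replacement gave an at least 7.4-fold higher number from compound 1 to compound 2 (0.87 log units; beyond the scatter). Both lie beyond the scatter. Compound 4 shares with compound 1 a ring holding nitrogen, but it also carries chlorine, whose effect has not been measured. A move back towards the value of compound 1 is therefore expected in this assay, meaning a lower number and a stronger inhibitor. The expected change is an at least 5.5-fold lower number from compound 3 to compound 4 (0.74 log units; beyond the scatter). For compound 4 the estimate is 1800 nM, with an expected range of 400 nM to 8000 nM.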

Compound 4, half-maximal inhibitory concentration: 270 nM
Estimate against measurement, compound 4: 6.7-fold (0.82 log units) above; measured number outside the range, below it.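

Among the compounds shown here, compound 4 gives the first reading of chloro on this ring: in this assay, chloro in place of hydrogen on an aromatic carbon makes the 1H-pyrrol-2-yl compound a stronger inhibitor (a 5.0-fold lower number from compound 1 to compound 4 (0.70 log units; beyond the scatter)), a modest step. Measured against the other two rings, the change is large (an at least 37-fold lower number from compound 3 to compound 4 (1.56 log units; beyond the scatter)) (an at least 37-fold lower number from compound 2 to compound 4 (1.56 log units; beyond the scatter)). Compound 2 and compound 3 each read as a limit and not a number, so both of these steps start from a limit: the limit of > 10000 nM in this assay, at which 2 of the 4 values shown sit.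

The compounds shown leave open whether bromo or methyl on the same ring carbon would match chloro, and whether chloro would also strengthen the furan-2-yl or 1,3-thiazol-2-yl compounds. Also open, as far as these compounds go, is how a carboxylic acid in place of the ethyl ester would read.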